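The compounds below may be only part of what the source reports. "The series", "measured", "known", "first", "only" and "open" are said of these compounds alone.

Compound 1 `Fc1cccc(-c2nc(Nc3ccc(Cl)cc3)c3cc(F)ccc3n2)c1` in a functional assay on U-937 cells (Homo sapiens) for cytotoxicity, read by MTT assay, with a stated time of 48 h (on this read-out lower numbers stand for stronger inhibition and higher numbers for weaker inhibition), gives 32700 nM. Compound 2 `Oc1ccc(Nc2nc(-c3cccc(F)c3)nc3ccc(F)cc23)cc1` in this assay reaches only the limit of the measurement, > 50000 nM.

Compound 2 thus stands at the limit, as the limit of > 50000 nM in this assay, at which 1 of the 2 values shown sits, records, and no number is known for it. Compound 3 `Oc1ccccc1Nc1nc(-c2cccc(F)c2)nc2ccc(F)cc12` differs from compound 2 by 2-hydroxyphenyl in place of 4-hydroxyphenyl on a nitrogen on an aromatic ring. Within the data shown here, the only measured step, an at least 1.5-fold higher number from compound 1 to compound 2 (0.18 log units; that floor lies within the scatter), concerns a different change, hydroxy in place of chloro on an aromatic carbon, and so does not bear on moving the hydroxy group; no measured pair isolates this change. Compound 1 gives 32700 nM in this assay. Compound 2 reaches only the limit. Compound 3 is therefore expected to sit in the same weak region, with a step that the limit leaves unreadable from compound 2 to compound 3. Compound 3 is estimated at 60000 nM, between 25000 nM and 150000 nM, with a fair chance that only a limit is reported again.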

Compound 3, half-maximal inhibitory concentration: 46300 nM
Estimate against measurement, compound 3: 1.3-fold (0.11 log units) above; measured number inside the range.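

Compound 3 gives a measured number where the hydroxy compound before it, compound 2, gave none, so 2-hydroxyphenyl on this nitrogen can be placed on the scale of this assay, while the printed floor says little about the size of the change (an at least 1.0-fold lower number from compound 2 to compound 3 (0.03 log units; that floor lies within the scatter)). Compound 2 itself remains only a limit: the limit of > 50000 nM in this assay, at which 1 of the 3 values shown sits. Set against 4-chlorophenyl at the same place, 2-hydroxyphenyl cannot be told apart from it (a 1.4-fold higher number from compound 1 to compound 3 (0.15 log units; within the scatter)), so these two groups on the nitrogen leave the read-out in one range.

On these data alone, how far the move of the hydroxy group really shifts the number stays open, as compound 2 has no number. As far as these compounds go, whether an amine or a methoxy group on this phenyl ring would give a step beyond the scatter also stays open.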